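Swapping an ether oxygen for fluorine in a short side chain

The compounds below may be only part of what the source reports. "The series", "measured", "known", "first", "only" and "open" are said of these compounds alone.

Compound 1 `COC(C)Cc1cc(C)cc(N)n1` sits at the limit of an assay on isolated protein for inhibition of Nitric oxide synthase, inducible (Homo sapiens), with a stated time of 30 min; on this read-out lower numbers stand for stronger inhibition and higher numbers for weaker inhibition: in this assay compound 1 gives > 5000 nM, a limit rather than a number. Compound 2 `Cc1cc(N)nc(CC(C)OCCF)c1` likewise gives only the limit > 5000 nM. Compound 3 `CC(C)=Cc1cc(C)cc(N)n1` gives 685 nM. Among the measured compounds shown here, the one step between measured neighbours, a step that the two limits leave unreadable from compound 1 to compound 2, cannot be read, because the limit of > 5000 nM in this assay, at which 2 of the 3 values shown sit, hides both ends. Compound 4 `Cc1cc(N)nc(CC(C)CCF)c1` differs from compound 1 by 2-fluoroethyl in place of methoxy on a saturated chain carbon bound to two saturated chain carbons. With no readable step to lean on and the shared core unchanged, compound 4 is expected near the same limit, so that the estimated step from compound 1 is an at least 1.2-fold lower number from compound 1 to compound 4 (0.09 log units; that floor lies within the scatter). The estimate for compound 4 in this assay is 4000 nM, between 1000 nM and 20000 nM.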

Compound 4, half-maximal inhibitory concentration: 731 nM
Estimate against measurement, compound 4: 5.5-fold (0.74 log units) above; the measured number lies below the stated range.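

On a saturated chain carbon bound to two saturated chain carbons, this side chain can clearly change the result: 2-fluoroethyl in place of methoxy gives an at least 6.8-fold lower number from compound 1 to compound 4 (0.83 log units; beyond the scatter) here, and 2-fluoroethyl in place of 2-fluoroethoxy gives an at least 6.8-fold lower number from compound 2 to compound 4 (0.83 log units; beyond the scatter) as well. Both chains with an ether oxygen thus give weaker inhibition than the chain without one. Both sizes are only floors, because each step starts from a limit: the limit of > 5000 nM in this assay, at which 2 of the 4 values shown sit.

On these data alone, how a plain propyl chain or an amine would read at this place stays open. The share of the fluorine in these steps therefore cannot be told.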